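Thiourea series: cytotoxicity notes before compound 4

A few compounds are considered here, and "the series" means these few. Any claim that something is new, unique, unknown or untested is made for them only; others in the source may bear on it.

Measured compounds:
- compound 1, `NC(=S)N1CCCc2c(OCCCCCOc3cccc4ccccc34)cccc21`, gives > 50000 nM in an ADME assay on Huh-7 cells (Homo sapiens) for cytotoxicity; a lower number here means that less compound is tolerated, a higher number that more compound is tolerated; this is a limit of the assay, not a number.
- compound 2, `O=C(NC(=S)N1CCc2c(OCc3ccccc3)cccc21)c1ccccc1`, gives > 50000 nM in this assay; again a limit.
- compound 3, `O=C(NC(=S)N1CCc2c(OCCCCCOc3ccc(Cl)cc3)cccc21)c1ccc(Br)cc1`, gives 29100 nM in this assay.

Compound 3 carries the only number among the three; the other two sit at a limit, as shown by the limit of > 50000 nM in this assay, at which 2 of the 3 values shown sit. For the measured compounds named here, no measured pair differs in one place, so no step size is established.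

Compound 4, `O=C(NC(=S)N1CCc2c(OCCCCCOc3ccc(Cl)cc3)cccc21)c1cccs1`, differs from compound 3 by thiophen-2-yl in place of 4-bromophenyl on a carbonyl carbon. Without a measured step, a small change is expected, if any, towards more compound tolerated. Compound 4 is expected at 40000 nM, between 18000 nM and 80000 nM. The expected step of a 1.4-fold higher number from compound 3 to compound 4 (0.14 log units; within the scatter) stays within the usual scatter.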

Compound 4, half-maximal cytotoxic concentration: 10700 nM
Compound 4: middle estimate off by 3.7-fold (0.57 log units), on the high side; measured number below the stated range.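

Thiophen-2-yl in place of 4-bromophenyl on a carbonyl carbon gives a 2.7-fold lower number from compound 3 to compound 4 (0.43 log units; beyond the scatter) in this assay, so this position does register in the read-out. For the compounds shown here, this is the first change in one place, and its step lies beyond the scatter. Compound 1 and compound 2 stay limits, not numbers, and add no step to this reading: the limit of > 50000 nM in this assay, at which 2 of the 4 values shown sit.

Going by these compounds, whether the step follows the loss of the bromine or the change of ring stays open. A pyridyl or 4-fluorophenyl group on this carbonyl carbon would be needed to separate the two.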